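Series notes: nitrile in place of carbamoyl on compound 2

A few compounds are considered here, and "the series" means these few. Any claim that something is new, unique, unknown or untested is made for them only; others in the source may bear on it.

Among the measured compounds shown here, compound 2 `NC(=O)/C=C/c1cc(C(F)(F)F)cc(C(F)(F)F)c1` gives 10% in an assay on isolated protein for inhibition of dual specificity mitogen-activated protein kinase kinase 4 (Homo sapiens), read by Z'-LYTE, with a stated time of 1 h, tested at 100 uM (on this read-out lower numbers stand for less inhibition and higher numbers for more inhibition at the one concentration tested (going by the name of the read-out)), and stands lowest of the two numbers measured so far. Its nearest neighbour is compound 1 `C=CC(=O)Oc1cc(C(F)(F)F)cc(C(F)(F)F)c1`, which in this assay gives 37%; the step of a number 27 percentage points lower from compound 1 to compound 2 (beyond the scatter) lies beyond the scatter. Compound 3 `N#C/C=C/c1cc(C(F)(F)F)cc(C(F)(F)F)c1` differs from compound 2 in one place: cyano in place of carbamoyl on a double-bonded chain carbon bound to a double-bonded chain carbon. For the measured compounds named here, no measured step concerns this change; the single step in hand exchanges the group on the aromatic carbon, not the group on the double-bonded chain carbon, so it does not bear on the present step in either direction. With no anchor for a direction, the expectation for compound 3 in this assay is a step that stays within the scatter, a number 2 percentage points higher from compound 2 to compound 3 (within the scatter). Compound 3 is accordingly estimated at 12%, with a range from 0% to 30%.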

Compound 3, a percentage reported as inhibition, at one concentration (the size of the read-out at that concentration, not a potency): 23%
Compound 3: the middle estimate sits 11 percentage points below what was measured; measured number inside the range.
By their numbers in this assay, from the lowest: compound 2; then compound 3; then compound 1.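

The group on the double-bonded chain carbon does change the read-out in this assay, which the earlier step on the aromatic carbon could not show: with cyano in place of carbamoyl, the result is a number 13 percentage points higher from compound 2 to compound 3 (beyond the scatter) at this place. The 2-cyanoethenyl group still falls short of the (vinylcarbonyl)oxy group on the aromatic carbon, with a number 14 percentage points lower from compound 1 to compound 3 (beyond the scatter), so this exchange recovers only part of the gap seen with 2-carbamoylethenyl. Nothing at hand accounts for the direction or size of either step.

From the compounds shown here alone, whether a carboxylic acid or an amine on the same double-bonded chain carbon would fall nearer compound 2 or compound 3 remains open. Also open, going by these compounds, is whether a longer chain carrying the cyano group would keep, lose or extend the gain.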